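Compound 3 to compound 4: a new side chain

This account rests on a few compounds, and the source may have more. Where it says the series, first, only, none or still open, it means among the compounds named here.

In an ADME assay on S9 fraction from liver (Rattus norvegicus, strain Sprague-Dawley) for metabolic stability, read by LC-MS, using NADPH, with stated times of 5 min and 60 min, tested at 5 uM (a lower number here means that less of the compound is left, a higher number that more of the compound is left), compound 3 `COc1cc(C2CN(C(=O)c3cc(OC[C@@H](O)CO)ccn3)C2)ccc1OCc1ccc(C2CC2)cc1` gives 61%. That is level, within the scatter, with compound 2 `COc1cc(C2CN(C(=O)c3cc(OC[C@H](O)CO)ccn3)C2)ccc1OCc1ccc(C2CC2)cc1` at 67%. Compound 1 `COc1ccc(COc2ccc(C3CN(C(=O)c4cc(OCCO)ccn4)C3)cc2OC)cc1` gives 49%, lower than compound 3 by more than the scatter.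

Compound 4 `COc1cc(C2CN(C(=O)c3cc(OCCCC(C)(C)C(=O)O)ccn3)C2)ccc1OCc1ccc(C2CC2)cc1` carries 3-carboxy-3-methylbutyl in place of 1,2-dihydroxyethyl, on a saturated chain carbon bound to an oxygen on an aromatic ring: 3-carboxy-3-methylbutyl in place of 1,2-dihydroxyethyl on a saturated chain carbon bound to an oxygen on an aromatic ring.

Among the measured compounds shown here, only one measured step bears on this, and only loosely. That step, a number 6 percentage points lower from compound 2 to compound 3 (within the scatter), stays within the scatter and rests on (the fact that compounds 2 and 3 differ only in the configuration as drawn). For the measured compounds named here, it covers the configuration of the chain, and no measured step replaces the chain itself. With compound 3 as the anchor at 61%, no shift beyond the scatter is expected in this assay, though the uncertainty is wide. The expected step is a number 2 percentage points lower from compound 3 to compound 4 (within the scatter). Compound 4 is estimated at 59%, with an expected range of 38% to 80%.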

Compound 4, percent of the compound remaining: 64%
Compound 4: middle estimate off by 5 percentage points, on the low side; low and high end bracket the measured number.
By their numbers in this assay, from the lowest: compound 1; then compounds 3, 4 and 2 (each within the scatter of the next).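

In this assay, putting 3-carboxy-3-methylbutyl in place of 1,2-dihydroxyethyl on a saturated chain carbon bound to an oxygen on an aromatic ring gives a number 3 percentage points higher from compound 3 to compound 4 (within the scatter), and against the other configuration of the diol it gives a number 3 percentage points lower from compound 2 to compound 4 (within the scatter). The earlier step spoke only to the configuration of the chain; these two show that the chain itself can be replaced, losing the defined stereocentre and both hydroxyl groups, with compound 4 staying level with compound 2 and compound 3. Nothing shown accounts for this level reading.

Still open, as far as these compounds go, is how a chain ending in an amine would read at this place in this assay. Also open, from the compounds shown here alone, is what the two methyl groups of 3-carboxy-3-methylbutyl contribute, set against an unbranched chain ending in the same carboxylic acid.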